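The compounds below may be only part of what the source reports. "The series", "measured", "known", "first", "only" and "open" are said of these compounds alone.

Compound 1, `C/N=C(\S)CCn1nc(-c2ccccc2)ccc1=O`, gives 68.2%; compound 2, `N=C(S)CCCCCn1nc(-c2ccccc2)ccc1=O`, gives 91.4%.

In a functional assay on the whole organism (stomach) for inhibition, with Rattus norvegicus as the target, at a dose of 100 mg/kg by the intraduodenal route (a lower number here means less inhibition, a higher number more inhibition at the dose given (going by the name of the read-out)), compound 2 stands highest of the two numbers shown, with compound 1 as its nearest neighbour, lower by the step of a number 23.2 percentage points higher from compound 1 to compound 2 (beyond the scatter). Compound 3, `O=c1ccc(-c2ccccc2)nn1CCC(=S)N1CCCC1`, has not yet been measured. It differs from compound 2 in one place: a group of 7 heavy atoms (5 carbon, 1 nitrogen, 1 sulfur; one five-membered non-aromatic ring with 1 hetero atom) in place of a group of 6 heavy atoms (4 carbon, 1 nitrogen, 1 sulfur; no ring), on a saturated chain carbon, two bonds along the chain from an aromatic nitrogen. Within the data shown here, the only measured step, from compound 1 to compound 2, also alters the group on a saturated chain carbon two bonds along the chain from an aromatic nitrogen, and it was modest. Among the measured compounds shown here, the change to compound 3 is of a different kind, exchanging two hydrogen-bond donors for a five-membered non-aromatic ring, so no measured step bears closely on it. Compound 3 is therefore expected to give 78%, in the range 50% to 95%, which means an expected step of a number 13.4 percentage points lower from compound 2 to compound 3 (beyond the scatter), likely within or just beyond the scatter.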

Compound 3, a percentage reported as inhibition, in the whole organism at one dose (the size of the read-out at that dose, not a potency): 38.2%
Estimate against measurement, compound 3: 39.8 percentage points above; measured number below the stated range.
By their numbers in this assay, from the lowest: compound 3; then compound 1; then compound 2.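

In this assay, placing the group with one five-membered non-aromatic ring with 1 hetero atom on this saturated chain carbon, two bonds along the chain from an aromatic nitrogen, gives a number 53.2 percentage points lower from compound 2 to compound 3 (beyond the scatter), a large step and the first to show that this position can cost much of the read-out. The same group also gives a number 30 percentage points lower from compound 1 to compound 3 (beyond the scatter), so it stands beneath both groups without a ring, the shorter as well as the longer. Nothing measured here explains this drop.

The entering group has 0 hydrogen-bond donors and a ring, while the group it replaces in compound 2 has 2 hydrogen-bond donors and no ring, so these compounds cannot separate the two changes. A dimethylamino group in the same place would keep the absence of donors without a ring, and a piperidine ring would show whether ring size matters.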